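Taking the halogens off the aryl group of compound 2

The compounds below may be only part of what the source reports. "The series", "measured", "known", "first", "only" and "open" are said of these compounds alone.

Among the compounds with values here, in an in vitro ADME assay on microsomes from liver (Rattus norvegicus) for metabolic stability (on this read-out higher numbers stand for fast clearance and lower numbers for slow clearance), three related compounds have numbers so far. Compound 1 `CC(C)NC(=O)[C@H]1CC[C@@H](n2/c(=N/C(=O)c3ccc(F)cc3)[nH]c3ccc(CN4CCC[C@H]4C(C)(C)O)cc32)CC1` gives 455 mL.min-1.g-1 on this read-out and compound 3 `CC(C)NC(=O)[C@H]1CC[C@@H](n2/c(=N/C(=O)c3ccc(F)cc3)[nH]c3ccc(CN4CCCCC4)cc32)CC1` gives 451 mL.min-1.g-1 on it. Within the data shown here, the one measured step between them is a 1.0-fold lower number from compound 1 to compound 3 (0.00 log units; within the scatter) and it concerns only the group on a saturated chain carbon. Compound 2 `CC(C)NC(=O)[C@H]1CC[C@@H](n2/c(=N/C(=O)c3cc(F)cc(Cl)c3)[nH]c3ccc(CN4CCC(C(C)(C)O)CC4)cc32)CC1` stands lowest at 43 mL.min-1.g-1 in this small set, and its gap to each of the other two lies beyond the scatter. However, compound 2 differs from both in more than one place, so that gap cannot be assigned to any single group.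

Compound 4 `CC(C)NC(=O)[C@H]1CC[C@@H](n2/c(=N/C(=O)c3ccccc3)[nH]c3ccc(CN4CCC(C(C)(C)O)CC4)cc32)CC1` has not been measured. It differs from compound 2 at one site: phenyl in place of 3-chloro-5-fluorophenyl on a carbonyl carbon with phenyl in place of 3-chloro-5-fluorophenyl on a carbonyl carbon. Among the measured compounds shown here, no measured step isolates this change, so the data give no firm direction. Compound 4 keeps the amine part of compound 2 and is therefore expected to stay near it, with a modest rise allowed for and a wide range. The estimated change is a 1.6-fold higher number from compound 2 to compound 4 (0.21 log units; within the scatter) and no step beyond the scatter is expected. Compound 4 is expected at about 70 mL.min-1.g-1 with an estimated range from 25 mL.min-1.g-1 to 200 mL.min-1.g-1 in this measurement.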

Compound 4, intrinsic clearance in microsomes: 21 mL.min-1.g-1
Compound 4: middle estimate off by 3.3-fold (0.52 log units), on the high side; the whole stated range lies above it.
By their numbers in this assay, from the lowest: compound 4; then compound 2; then compounds 3 and 1 (each within the scatter of the next).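

In this assay, the change at this position now has a measured step of its own: phenyl in place of 3-chloro-5-fluorophenyl on the carbonyl carbon gives a 2.0-fold lower number from compound 2 to compound 4 (0.31 log units; beyond the scatter), a modest step that lies just beyond the scatter. Within the data shown here, the only earlier step concerned the group on a saturated chain carbon and stayed within the scatter, so this is the first change at a single place in this set that moves the number. It also shows that the low number of compound 2 does not depend on the two halogens, since the plain phenyl of compound 4 goes with a lower number still. Nothing at hand bears on why the number falls when the halogens leave.

Going by these compounds, whether the chlorine or the fluorine accounts for the step stays open, as both leave together, and how a 3-chlorophenyl or a 3-methoxyphenyl would compare on this carbonyl carbon is unknown. Also open, on these data alone, is how the 4-fluorophenyl of compound 1 and compound 3 would behave with the amine part of compound 4, as those two differ from compound 4 in more than one place.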